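The source may hold more compounds than are shown below. What is called first, only, known or untested is meant among the compounds shown, and "the series" means these compounds.

Compound 1 `COc1ccc(Nc2nc(N[C@H]3CC[C@H](N)CC3)nc3c2ncn3CCC(C)C)c(OC)c1`: 7900 nM
Compound 2 `N[C@H]1CC[C@H](Nc2nc(Nc3cccc(Cl)c3)c3ncn(Cc4ccccc4)c3n2)CC1`: 10200 nM

Among these two, compound 1 has the lower number in a functional assay on BT-474 cells (Homo sapiens) for inhibition, read by fluorescence, with a stated time of 72 h (a lower number here means a stronger inhibitor of growth, a higher number a weaker inhibitor of growth), yet compound 2 lies within the usual scatter of it, so the two cannot be separated on the numbers at hand. Within the data shown here, they differ in more than one place, and no single step between them has been worked out; only their two values are known.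

Compound 3 `CC(C)CCn1cnc2c(Nc3ccc(O)cc3)nc(N[C@H]3CC[C@H](N)CC3)nc21` has not yet been measured. It is derived from compound 1 by one change: 4-hydroxyphenyl in place of 2,4-dimethoxyphenyl on a nitrogen on an aromatic ring. The leaving group is the larger of the two. Among the measured compounds shown here, no measured step of this kind exists here to lean on, so the expectation for this assay is cautious: a small shift, most likely not beyond the scatter, in either direction. The step this expectation means is a 1.3-fold lower number from compound 1 to compound 3 (0.12 log units; within the scatter), which is expected to be modest. Compound 3 is expected to come in near 6000 nM, within a range from 2000 nM to 20000 nM.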

Compound 3, concentration for 50% growth inhibition: 7700 nM
For compound 3 the middle estimate is 1.3-fold (0.11 log units) below the measured one; measured number inside the range.
By their numbers in this assay, from the lowest: compounds 3, 1 and 2 (each within the scatter of the next).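

In this assay the exchange of 2,4-dimethoxyphenyl for 4-hydroxyphenyl on this nitrogen gives a 1.0-fold lower number from compound 1 to compound 3 (0.01 log units; within the scatter) and so the two compounds cannot be told apart. This position therefore accepts a group with fewer heavy atoms and a hydrogen-bond donor that the leaving group lacks, with no difference visible in this growth read-out. Nothing measured here offers a reason for this result.

Among these compounds, only this one exchange can be read at this position, so it remains open whether a phenyl ring carrying an amine or a carboxylic acid on this nitrogen would stand apart from compound 1. On these data alone, it is also open whether 4-hydroxyphenyl would behave the same way if the chain on the shared core were longer.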